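This account rests on a few compounds, and the source may have more. Where it says the series, first, only, none or still open, it means among the compounds named here.

In a functional assay on HCT-116 cells (Homo sapiens) (a higher number here means a weaker inhibitor of growth, a lower number a stronger inhibitor of growth), compound 2 `COc1ccccc1-c1cc(O)c2cccnc2n1` gives 27500 nM and compound 1 `COc1ccccc1-c1cc(O)c2ccc(C)nc2n1` gives 38000 nM, so the two stand within the scatter of each other. Compound 3 `COc1ccccc1-c1cc(O)c2c(C)ccnc2n1` differs from compound 2 in one place: methyl in place of hydrogen on an aromatic carbon, opposite the ring nitrogen. Among the compounds with values here, the only measured step that bears on this is a 1.4-fold lower number from compound 1 to compound 2 (0.14 log units; within the scatter), which also exchanges methyl and hydrogen on an aromatic carbon, though at another place, and it stays within the scatter. No step beyond the scatter is therefore expected in this assay. The step expected is a 1.1-fold higher number from compound 2 to compound 3 (0.04 log units; within the scatter). For compound 3 the estimated value is 30000 nM, with an expected range from 14000 nM to 60000 nM.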

Compound 3, concentration for 50% growth inhibition: 7590 nM
The estimate for compound 3 lay 4.0-fold (0.60 log units) above the measured number; measured number outside the range, below it.
By their numbers in this assay, from the lowest: compound 3; then compounds 2 and 1 (each within the scatter of the next).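

In this assay, methyl in place of hydrogen opposite the ring nitrogen gives a 3.6-fold lower number from compound 2 to compound 3 (0.56 log units; beyond the scatter) and so moves the number modestly beyond the scatter. The same exchange at another place gave only a 1.4-fold lower number from compound 1 to compound 2 (0.14 log units; within the scatter) within the scatter, so in these compounds the effect of methyl depends on where it sits on the shared core. Nothing shown explains why this position differs. From the compounds shown here alone, whether ethyl or an amine at this position would lower the number further remains open, as does whether the step would hold with another group in place of the methoxy-bearing aromatic ring.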